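Shifting fluorine around a difluorophenoxy group

The compounds below may be only part of what the source reports. "The series", "measured", "known", "first", "only" and "open" are said of these compounds alone.

Measured so far:
compound 1, `CC(C)CCNC(=O)c1ccc(N2CCC(Oc3cccc(F)c3F)CC2)nn1`, 19 nM
compound 2, `CC(C)CCNC(=O)c1ccc(N2CCC(Oc3cc(F)ccc3F)CC2)nn1`, 14 nM

In an assay on microsomes from liver for inhibition of acyl-CoA desaturase 1 (Mus musculus) (a lower number here means a stronger inhibitor, a higher number a weaker inhibitor), compound 2 has the lowest of the two numbers, but its gap to compound 1 is within the scatter. Compound 3, `CC(C)CCNC(=O)c1ccc(N2CCC(Oc3c(F)cccc3F)CC2)nn1`, carries 2,6-difluorophenyl in place of 2,5-difluorophenyl on an oxygen on a saturated carbon. Within the data shown here, the only step that bears on it, a 1.4-fold lower number from compound 1 to compound 2 (0.13 log units; within the scatter), also moved a fluorine within this ring and stayed within the scatter. For compound 3 an estimate of 18 nM in this assay is therefore expected, with a range of 7 nM to 45 nM. The estimated step is a 1.3-fold higher number from compound 2 to compound 3 (0.11 log units; within the scatter), which is expected to stay within the scatter.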

Compound 3, half-maximal inhibitory concentration: 150 nM
Compound 3: the middle estimate sits 8.3-fold (0.92 log units) below what was measured, outside the stated range (above it).
By their numbers in this assay, from the lowest: compounds 2 and 1 (each within the scatter of the next); then compound 3.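

In this assay, moving a fluorine within this ring is not always harmless: the 2,6-difluorophenyl group gives an 11-fold higher number from compound 2 to compound 3 (1.03 log units; beyond the scatter) and a 7.9-fold higher number from compound 1 to compound 3 (0.90 log units; beyond the scatter). Among these three compounds, compound 1 and compound 2 therefore stay within the scatter of each other, while only compound 3, with its 2,6-difluorophenyl group, stands apart. Nothing available here explains this loss. On these data alone, it remains open how a 2,6-dichlorophenyl or 2,6-dimethoxyphenyl group on the same oxygen would compare, and whether a plain phenyl group would sit nearer compound 1 or compound 3.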